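Removing Bromine and Hydroxy From the Amide Aryl Group

A few compounds are considered here, and "the series" means these few. Any claim that something is new, unique, unknown or untested is made for them only; others in the source may bear on it.

Three amides built on one shared core have been measured in an assay for inhibition of HSP60/HSP10 (Homo sapiens), with a stated time of 60 min; on this read-out higher numbers stand for weaker inhibition and lower numbers for stronger inhibition. Compound 1 `COc1ccc(Br)cc1C(=O)Nc1ccc(Sc2nc3ccccc3s2)cc1` reaches only a limit, giving > 100000 nM. Compound 2 `O=C(Nc1ccc(Sc2nc3ccccc3s2)cc1)c1cccc(Br)c1` likewise stops at a limit, with > 100000 nM. Compound 3 `O=C(Nc1ccc(Sc2nc3ccccc3s2)cc1)c1cc(Br)ccc1O` also sits at a limit, with > 100000 nM. Because all three values share the limit of > 100000 nM in this assay, at which 3 of the 3 values shown sit, none of the steps among them can be read: the step that the two limits leave unreadable from compound 1 to compound 2, the step that the two limits leave unreadable from compound 1 to compound 3 and the step that the two limits leave unreadable from compound 2 to compound 3 are all of unknown size. Compound 3 therefore stands at the limit, indistinguishable on the numbers shown from the other two.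

Compound 4 `O=C(Nc1ccc(Sc2nc3ccccc3s2)cc1)c1ccccc1` differs from compound 3 in one place: phenyl in place of 5-bromo-2-hydroxyphenyl on a carbonyl carbon. Among the compounds with values here, no measured step bears directly on this change, and the steps that exist are unreadable, so the data give no direction. The step that the limit leaves unreadable from compound 3 to compound 4 is expected to stay within the scatter. Compound 4 is estimated at 150000 nM in this assay, with a range from 40000 nM to 600000 nM, most likely again reported only as a limit.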

Compound 4, half-maximal inhibitory concentration: > 100000 nM
Compound 4: a limit, no number; the forecaster's own chance of this, stated with the estimate: 80%; the middle value lies beyond the limit too.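

In this assay, within the data shown here, no step from compound 4 to compound 1, compound 2 or compound 3 can be read, and none of the four gives a number: the limit of > 100000 nM in this assay, at which 4 of the 4 values shown sit.

The compounds shown leave open whether changing the amide aryl group alters inhibition, and how far each compound lies beyond the limit.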